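From phenoxy to (sec-butyl)sulfanyl: a step past two limits

This account rests on a few compounds, and the source may have more. Where it says the series, first, only, none or still open, it means among the compounds named here.

Compound 1 (`CCC(CC)O[C@@H]1C=C(C(=O)O)C[C@H](NCc2ccc(OC)cc2)[C@H]1NC(C)=O`) gives > 200000 nM as a limit
Compound 2 (`CCC(CC)O[C@@H]1C=C(C(=O)O)C[C@H](NCc2ccc(Oc3ccccc3)cc2)[C@H]1NC(C)=O`) gives > 200000 nM as a limit

Both entries come from an ADME assay on cells (Fibroblast, Gallus gallus) for cytotoxicity, read by CCK-8 assay, with a stated time of 48 h (a lower number here means that less compound is tolerated, a higher number that more compound is tolerated), and are limits, not numbers. Among the compounds with values here, compound 2 therefore stands without an exact value, and so does the only other measured compound (the limit of > 200000 nM in this assay, at which 2 of the 2 values shown sit).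

Compound 3 (`CCC(CC)O[C@@H]1C=C(C(=O)O)C[C@H](NCc2ccc(SC(C)CC)cc2)[C@H]1NC(C)=O`) has not yet been measured. It keeps the shared core of compound 2 and differs in one place ((sec-butyl)sulfanyl in place of phenoxy on an aromatic carbon). In plain words, (sec-butyl)sulfanyl takes the place of phenoxy on an aromatic carbon, para to a large group.

Within the data shown here, the one measured step that changes this same group (a step that the two limits leave unreadable from compound 1 to compound 2) offers no size to carry over. The expectation therefore rests on compound 2 at > 200000 nM as a limit, and no change beyond the scatter is expected in either direction in this assay for this swap. The estimated step (a number no higher from compound 2 to compound 3 (the limit leaves the size open)) is expected to be small. For compound 3 the estimated value is 200000 nM with an expected range of 80000 nM to 400000 nM in this test. A report that again gives only a limit is the likeliest outcome.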

Compound 3, half-maximal cytotoxic concentration: > 200000 nM
Compound 3 ended at the assay's limit; the forecaster's own chance of this, stated with the estimate: 80%; the middle value lies on the limit itself.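

Compound 1, compound 2 and compound 3 all sit at the same limit of this assay, so no step among them can be read, in size or in direction: the limit of > 200000 nM in this assay, at which 3 of the 3 values shown sit.

The compounds shown leave open whether methoxy, phenoxy and (sec-butyl)sulfanyl differ at all in this assay, and at what concentration any of the three would reach its half-maximal cytotoxic effect.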